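Three aryl variants measured, a cycloheptyl variant expected

A few compounds are considered here, and "the series" means these few. Any claim that something is new, unique, unknown or untested is made for them only; others in the source may bear on it.

Compound 1 `Nc1scc(CN2CCN(c3ccc(Cl)cc3Cl)CC2)c1C(=O)c1ccc(Cl)cc1` gives -54% in a functional assay on CHO cells with adenosine receptor A1 (Homo sapiens) as the target, read by cAMP accumulation and immunoassay, with a stated time of 6 min, tested at 1 uM; on this read-out higher numbers stand for a weaker effect at the one concentration tested and lower numbers for a stronger effect.
Compound 2 `Nc1scc(CN2CCN(c3cccc(Cl)c3Cl)CC2)c1C(=O)c1ccc(Cl)cc1` gives -57%.
Compound 3 `Nc1scc(CN2CCN(c3ccc(OC(F)(F)F)cc3)CC2)c1C(=O)c1ccc(Cl)cc1` gives -51%.

On the numbers shown, compound 3 stands at the top of the three, yet a number 3 percentage points higher from compound 1 to compound 3 (within the scatter) and a number 6 percentage points higher from compound 2 to compound 3 (within the scatter) lie within the scatter, so the three are not separated. Compound 4 `Nc1scc(CN2CCN(C3CCCCCC3)CC2)c1C(=O)c1ccc(Cl)cc1` differs from compound 3 by cycloheptyl in place of 4-(trifluoromethoxy)phenyl on an amine nitrogen in a ring. Among the measured compounds shown here, no measured step exchanges an aromatic group for a saturated ring; the only comparisons, a number 3 percentage points lower from compound 1 to compound 2 (within the scatter), a number 3 percentage points higher from compound 1 to compound 3 (within the scatter) and a number 6 percentage points higher from compound 2 to compound 3 (within the scatter), swap one aromatic group for another and all stay within the scatter. The step of a number 6 percentage points higher from compound 3 to compound 4 (within the scatter) is therefore an estimate with little support, and a wide range is appropriate. Compound 4 is expected to give -45%, between -75% and -10%.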

Compound 4, a percentage reported as activity, at one concentration (the size of the read-out at that concentration, not a potency): 3.7%
Compound 4: the middle estimate sits 48.7 percentage points below what was measured, and the stated range ends below it.
By their numbers in this assay, from the lowest: compounds 2, 1 and 3 (each within the scatter of the next); then compound 4.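

In this assay swapping one aromatic group for another on the amine nitrogen in a ring stayed within the scatter, but cycloheptyl brings a number 54.7 percentage points higher from compound 3 to compound 4 (beyond the scatter) and a number 60.7 percentage points higher from compound 2 to compound 4 (beyond the scatter) and a number 57.7 percentage points higher from compound 1 to compound 4 (beyond the scatter) on the same read-out. This position therefore does respond to the group it carries, and the one saturated ring shown stands apart from all three aromatic groups, with the weaker effect at the one concentration tested. No evidence bears on why this happens.

As far as these compounds go, it remains open whether the shift follows the loss of the aromatic ring or belongs to cycloheptyl itself. Unsubstituted phenyl, cyclohexyl or benzyl on that nitrogen would help to separate the two.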